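Removing the ring on the aromatic carbon: expected loss

The source may hold more compounds than are shown below. What is called first, only, known or untested is meant among the compounds shown, and "the series" means these compounds.

In an ADME assay on microsomes from liver (Rattus norvegicus) for metabolic stability, using NADPH, with a stated time of 10 min (a higher number here means that more of the compound is left, a lower number that less of the compound is left), compound 2 `CCCCc1nc(=O)c(S(=O)(=O)c2ccc(-n3ccccc3=O)cc2)c(O)n1-c1c(OC)cccc1OC` gives 83%, the highest of the two numbers measured, while compound 1 `CCCCc1nc(=O)c(S(=O)(=O)c2ccc(-c3cccnc3)cc2)c(O)n1-c1c(OC)cccc1OC` gives 3%. Among the compounds with values here, the only measured step, a number 80 percentage points higher from compound 1 to compound 2 (beyond the scatter), shows how strongly the group on that aromatic carbon sways this assay. Compound 3 `CCCCc1nc(=O)c(S(=O)(=O)c2ccccc2)c(O)n1-c1c(OC)cccc1OC` differs from compound 2 in that (a hydrogen atom in place of a group of 7 heavy atoms (5 carbon, 1 nitrogen, 1 oxygen; one six-membered aromatic ring with 1 hetero atom), on an aromatic carbon). Within the data shown here, no measured step covers this removal, so the expectation rests only on the size of the gain from compound 1 to compound 2. Compound 3 is therefore expected to give 35%, with an estimated range from 5% to 75%. The step this estimate implies is a number 48 percentage points lower from compound 2 to compound 3 (beyond the scatter), a drop well beyond the scatter.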

Compound 3, percent of the compound remaining: 93%
Compound 3: the middle estimate sits 58 percentage points below what was measured; measured number outside the range, above it.
By their numbers in this assay, from the lowest: compound 1; then compounds 2 and 3 (each within the scatter of the next).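

In this assay, the step with hydrogen in place of the larger group is a number 10 percentage points higher from compound 2 to compound 3 (within the scatter), so this assay does not separate that group from hydrogen on this aromatic carbon. The other new step, a number 90 percentage points higher from compound 1 to compound 3 (beyond the scatter), sets pyridin-3-yl apart from hydrogen, so among these three compounds only pyridin-3-yl stands apart at this position. Nothing given here accounts for this difference. On these data alone, whether a simple phenyl ring, an amine or a carboxylic acid on this carbon would group with hydrogen or with pyridin-3-yl stays open.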